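Amide side chain change from compound 2 to compound 3

A few compounds are considered here, and "the series" means these few. Any claim that something is new, unique, unknown or untested is made for them only; others in the source may bear on it.

Measured so far, in a functional assay on BXPC-3 cells (Homo sapiens) for antiproliferative activity, read by MTT assay, with a stated time of 24 h; on this read-out lower numbers stand for stronger inhibition and higher numbers for weaker inhibition
Compound 1 `CCn1c(C(=O)NCCCO)ccc1C(CC)(CC)c1ccc(OCS(=O)(=O)c2ccccc2)c(C)c1` gives 26600 nM in this series
Compound 2 `CCn1c(C(=O)N[C@H](CO)CCO)ccc1C(CC)(CC)c1ccc(OCS(=O)(=O)c2ccccc2)c(C)c1` gives 15900 nM in this series

Compound 2, at 15900 nM in this assay, lies within the scatter of compound 1, so the two cannot be ranked. Compound 3 `CCn1c(C(=O)NCC(=O)O)ccc1C(CC)(CC)c1ccc(OCS(=O)(=O)c2ccccc2)c(C)c1` changes the same side chain (carboxymethyl in place of 3-hydroxy-1-(hydroxymethyl)propyl on an amide-type nitrogen): carboxymethyl in place of 3-hydroxy-1-(hydroxymethyl)propyl on an amide-type nitrogen. Among the measured compounds shown here, one measured step bears on this, a 1.7-fold lower number from compound 1 to compound 2 (0.22 log units; within the scatter), and it stayed small. For the measured compounds named here, no measured compound carries carboxymethyl, so the direction remains open, and a step of similar size, leaning to a higher number, is expected. The estimate means a 1.6-fold higher number from compound 2 to compound 3 (0.20 log units; within the scatter) as the expected move. Compound 3 is estimated at 25000 nM in this assay, with an expected range from 10000 nM to 60000 nM for repeat measurements.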

Compound 3, half-maximal inhibitory concentration: > 50000 nM
Compound 3: no number, only a limit (the forecaster's own chance of this, stated with the estimate: 15%); at least 2.0-fold (0.30 log units) between middle value and limit.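

In this assay compound 3 stands as a limit and not a number: the limit of > 50000 nM in this assay, at which 1 of the 3 values shown sits. Among the compounds shown here, the side chain on the amide-type nitrogen had so far given only a step within the scatter, whereas carboxymethyl in place of 3-hydroxy-1-(hydroxymethyl)propyl gives an at least 3.1-fold higher number from compound 2 to compound 3 (0.49 log units; beyond the scatter), so this position does respond to the group it carries. On these data alone, the companion change, carboxy in place of 2-hydroxyethyl, reads an at least 1.8-fold higher number from compound 1 to compound 3 (0.27 log units; that floor lies within the scatter), which adds only a floor, and the full size of both steps stays unknown.

As far as these compounds go, whether the carboxylic acid itself or the chain length goes with the weaker reading stays open. A carboxypropyl chain, a methyl ester of the acid or an aminoethyl chain on the same nitrogen would bear on that question.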